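This account rests on a few compounds, and the source may have more. Where it says the series, first, only, none or still open, it means among the compounds named here.

Compound 2 `Nc1cc(N)c2nc(-c3ccccc3)c(NCc3ccc(F)cc3)nc2c1` is one of three compounds followed in a functional assay on SK-MEL-2 cells (Homo sapiens) for inhibition, read by sulforhodamine B assay, with a stated time of 48 h (a higher number here means that more compound is tolerated, a lower number that less compound is tolerated), the others being compound 1 `COc1ccc(CNc2nc3cc(N)cc(N)c3nc2-c2ccccc2)cc1OC` and compound 3 `COc1ccc(CNc2nc3cc(N)cc(N)c3nc2-c2ccccc2)cc1`. In this assay compound 2 gives only a limit, < 100000 nM. Compound 1 likewise gives only a limit, < 100000 nM. Compound 3 gives a number, 57500 nM. Because of the limit of < 100000 nM in this assay, at which 2 of the 3 values shown sit, the step from compound 1 to compound 2 a step that the two limits leave unreadable from compound 1 to compound 2 cannot be sized, and the same holds for the step from compound 1 to compound 3 a step that the limit leaves unreadable from compound 1 to compound 3 and the step from compound 2 to compound 3 a step that the limit leaves unreadable from compound 2 to compound 3. Compound 4 `Nc1cc(N)c2nc(-c3ccccc3)c(Sc3ccc(Cl)c(Cl)c3)nc2c1` departs from compound 2 by (3,4-dichlorophenyl)sulfanyl in place of (4-fluorobenzyl)amino on an aromatic carbon. For the measured compounds named here, none of the measured steps involves an exchange of this kind, and none of them yields a readable size, so the only anchor is the high position of compound 2 and compound 3 in this assay. Compound 4 is therefore expected near 45000 nM, within 12000 nM to 100000 nM. The step from compound 2 to compound 4 that this estimate implies, a step that the limit leaves unreadable from compound 2 to compound 4, is expected to stay within the scatter.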

Compound 4, concentration lethal to 50% of the cells: < 100000 nM
Compound 4 was reported as a limit; the forecaster's own chance of this, stated with the estimate: 40%; the middle value lies beyond the limit too.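

In this assay compound 4 gives only a limit, < 100000 nM. No step can be read between compound 2 and compound 4, because both stand at a limit: the limit of < 100000 nM in this assay, at which 3 of the 4 values shown sit.

The compounds shown leave open whether (3,4-dichlorophenyl)sulfanyl in place of (4-fluorobenzyl)amino changes the value at all.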